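Trisubstituted anilines: methacryloyl to acryloyl amide step

The compounds below may be only part of what the source reports. "The series", "measured", "known", "first", "only" and "open" are said of these compounds alone.

Measured so far:
compound 1 `COc1ccc(CNc2cc(OC)c(OC)c(OC)c2)cc1C`: 73800 nM
compound 2 `C=C(C)C(=O)N(Cc1ccc(OC)c(O)c1)c1cc(OC)c(OC)c(OC)c1`: 200 nM

In a functional assay on KYSE-450 cells (Homo sapiens) for inhibition, read by MTT assay, with a stated time of 48 h (a lower number here means a stronger inhibitor, a higher number a weaker inhibitor), compound 1 gives 73800 nM. In this assay compound 2 gives 200 nM, the lowest of the two numbers and far beyond the scatter from compound 1; the two compounds differ in several places at once, so no single step can be read from that gap.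

Compound 3 `C=CC(=O)N(Cc1ccc(OC)c(O)c1)c1cc(OC)c(OC)c(OC)c1` is not yet measured. Its difference from compound 2 is hydrogen in place of methyl on a double-bonded chain carbon bound to a carbonyl carbon. Only one carbon leaves, at the (1-methylethenyl)carbonyl group, which becomes vinylcarbonyl. Among the compounds with values here, no measured pair isolates such a change, so the size of the step rests on the small extent of the change alone.

Compound 3 is expected to give 150 nM, with a range from 50 nM to 500 nM. The implied step, a 1.3-fold lower number from compound 2 to compound 3 (0.12 log units; within the scatter), is expected to fall within the scatter or at most a little toward a lower number.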

Compound 3, half-maximal inhibitory concentration: 160 nM
For compound 3 the middle estimate is 1.1-fold (0.03 log units) below the measured one, and the stated range covers the measured number.
By their numbers in this assay, from the lowest: compounds 3 and 2 (each within the scatter of the next); then compound 1.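

In this assay, within the data shown here, hydrogen in place of methyl on a double-bonded chain carbon bound to a carbonyl carbon gives a 1.3-fold lower number from compound 2 to compound 3 (0.10 log units; within the scatter) and is the first step that changes one place only. At this place, the methyl of the (1-methylethenyl)carbonyl group is not required to hold the number at this level, as the vinylcarbonyl group of compound 3 reads the same within the scatter. Nothing at hand bears on why the two amides read alike.

The role of the whole acyl group stays unread, as compound 1 differs from compound 2 in several places and that gap cannot be read as a step. Whether a saturated propanoyl group, or an amine or a longer chain on the double-bonded carbon, would hold the number in this assay is open.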